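The compounds below may be only part of what the source reports. "The series", "measured", "known", "first", "only" and "open" are said of these compounds alone.

Compound 1 `CCCCCCCCc1ccc(OC(C)C(=O)Cn2nnc(-c3ccc(Cl)cc3)n2)cc1` gives 72% in an ADME assay on S9 fraction from liver (Rattus norvegicus) for metabolic stability, read by LC-MS, using NADPH, with a stated time of 30 min; on this read-out lower numbers stand for a less stable compound and higher numbers for a more stable compound.
Compound 2 `CC(Oc1ccc(Oc2ccc(C(F)(F)F)cc2)cc1)C(=O)Cn1nnc(-c2ccc(Cl)cc2)n1` gives 9%.

Compound 2 stands lowest of these two, well under compound 1, as the step of a number 63 percentage points lower from compound 1 to compound 2 (beyond the scatter) shows. Compound 3 `COC(=O)c1ccc(-c2nnn(CC(=O)C(C)Oc3ccc(Oc4ccc(C(F)(F)F)cc4)cc3)n2)cc1` differs from compound 2 by methoxycarbonyl in place of chloro on an aromatic carbon. Among the measured compounds shown here, no measured step touches this group: the single measured step altered a different part of the shared core, so it gives no direct guide. Compound 2 already sits near the bottom of the scale. Compound 3 is therefore expected to stay close, with an estimated step of a number 1 percentage points lower from compound 2 to compound 3 (within the scatter), not beyond the scatter. The estimate for compound 3 is 8%, within 0% to 25%.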

Compound 3, percent of the compound remaining: 15%
Beside the measured number, compound 3's estimate is 7 percentage points below it, and the stated range covers the measured number.
By their numbers in this assay, from the lowest: compounds 2 and 3 (each within the scatter of the next); then compound 1.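

Among the compounds shown here, the swap from 4-chlorophenyl to 4-(methoxycarbonyl)phenyl gives the first reading at this position, on an aromatic carbon para to a large group: in this assay, the step is a number 6 percentage points higher from compound 2 to compound 3 (within the scatter). At this position and against this background, replacing chloro with the larger methoxycarbonyl therefore produces no change beyond the scatter. Nothing measured here explains this result.

As far as these compounds go, whether an amine or a carboxylic acid at this position would give a different reading remains open. So does whether methoxycarbonyl would behave the same way with octyl in place of 4-(trifluoromethyl)phenoxy.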